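A few compounds are considered here, and "the series" means these few. Any claim that something is new, unique, unknown or untested is made for them only; others in the source may bear on it.

Going by the values given here, compound 1 `C=CCc1ccc(O)c(-c2ccc(OCc3ccccc3)c(CC=C)c2)c1` is the only compound here with a measured number in a functional assay on CNE2Z cells (Homo sapiens) for inhibition, read by MTT assay, with a stated time of 72 h; a lower number here means a stronger inhibitor, a higher number a weaker inhibitor: compound 1 gives 30300 nM. Compound 2 `C=CCc1ccc(OCc2ccc(Cl)c(Cl)c2)c(-c2ccc(OCc3ccc(Cl)c(Cl)c3)c(CC=C)c2)c1` is also shown, but in this assay compound 2 reaches only a limit of the assay, > 50000 nM, and that limit holds one of the two values shown, as noted in the limit of > 50000 nM in this assay, at which 1 of the 2 values shown sits. Among the compounds with values here, no step between two measured compounds is available, so nothing about the size of any single change can be read from the measurements themselves.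

Compound 3 `C=CCc1ccc(O)c(-c2ccc(OCc3c(Cl)cccc3Cl)c(CC=C)c2)c1` is not yet measured. It differs from compound 1 in one place: 2,6-dichlorophenyl in place of phenyl on a saturated chain carbon bound to an oxygen on an aromatic ring. Within the data shown here, the expectation for this change rests on little, since the only other compound carrying dichlorobenzyl groups, compound 2, gives a limit rather than a number and differs from compound 1 in more than one place. The author therefore expects a step from compound 1 to compound 3 of a 1.2-fold higher number from compound 1 to compound 3 (0.06 log units; within the scatter), that is, no change beyond the scatter of this assay, with a modest lean toward weaker inhibition. In this assay compound 3 is estimated at 35000 nM, within a range of 12000 nM to 100000 nM.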

Compound 3, half-maximal inhibitory concentration: 16400 nM
Estimate against measurement, compound 3: 2.1-fold (0.33 log units) above; measured number inside the range.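

In this assay, going by these compounds alone, the benzyl to 2,6-dichlorobenzyl change gives the first step that can be read between two measured compounds: a 1.8-fold lower number from compound 1 to compound 3 (0.27 log units; within the scatter). This shows that, on a saturated chain carbon bound to an oxygen on an aromatic ring, 2,6-dichlorophenyl can stand in place of phenyl without a difference that can be told apart from repeat measurements, and the inhibition stays measurable as a number. Compound 2 remains a limit of the assay and not a number, and it differs from compound 1 in more than one place, so it gives no second step to set beside this one: the limit of > 50000 nM in this assay, at which 1 of the 3 values shown sits.

What the compounds shown leave open is whether any other group on this benzyl ring, such as an amine, a carboxylic acid or a methoxy group, would move the number beyond the scatter. They also leave open whether a longer chain between the oxygen and the ring would do so, and why the two dichlorobenzyl groups of compound 2 end at a limit cannot be read from them.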